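The source may hold more compounds than are shown below. What is called first, only, known or untested is meant among the compounds shown, and "the series" means these compounds.

Measured compounds, with values from a functional assay on MDA-MB-231 cells (Homo sapiens) for antiproliferative activity, read by MTT assay, with a stated time of 72 h (a higher number here means a weaker inhibitor, a lower number a stronger inhibitor), as follows:
Compound 1 `O=C(CCc1cccc2c1B(O)OC2)Nc1cccc(Br)c1` gives 720 nM
Compound 2 `COc1ccc(-c2cccc(NC(=O)CCc3cccc4c3B(O)OC4)c2)cc1` gives 88 nM

Of these two, compound 2 has the lower number and so is the stronger inhibitor in this assay by a margin beyond the scatter. Compound 3 `O=C(CCc1cccc2c1B(O)OC2)Nc1cccc(-c2cccc(C(F)(F)F)c2)c1` has not yet been measured. It has 3-(trifluoromethyl)phenyl in place of 4-methoxyphenyl on an aromatic carbon, meta to a large group (3-(trifluoromethyl)phenyl in place of 4-methoxyphenyl on an aromatic carbon).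

For the measured compounds named here, only one measured step bears on this change. Putting 4-methoxyphenyl in place of bromo gave an 8.2-fold lower number from compound 1 to compound 2 (0.91 log units; beyond the scatter) and this modest gain came at the same place. Compound 3 keeps a six-membered aromatic ring of carbon only there, so it does not reverse that step. Going by the values given here, no measured pair compares one such ring with another, so the data give no firm direction. A small move towards a higher number, within the scatter, is expected (a 1.4-fold higher number from compound 2 to compound 3 (0.13 log units; within the scatter)). The estimate for compound 3 is 120 nM (expected range 40 nM to 350 nM).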

Compound 3, half-maximal inhibitory concentration: 410 nM
Compound 3: the middle estimate sits 3.4-fold (0.53 log units) below what was measured, outside the stated range (above it).
By their numbers in this assay, from the lowest: compound 2; then compounds 3 and 1 (each within the scatter of the next).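

For the compounds shown here, the earlier compounds showed only that an aromatic ring at this position could outdo bromo. In this assay, exchanging one aromatic ring for another now produces a clear loss (a 4.7-fold higher number from compound 2 to compound 3 (0.67 log units; beyond the scatter)), so among these compounds the gain does not follow from having a six-membered aromatic ring of carbon only at this place, and it depends on which ring is attached. Measured against bromo, the 3-(trifluoromethyl)phenyl group gives a difference that cannot be told from the scatter (a 1.8-fold lower number from compound 1 to compound 3 (0.24 log units; within the scatter)), whereas 4-methoxyphenyl keeps its gain, and nothing available accounts for this difference between the two rings.

The two rings differ both in the group they carry and in where that group sits, so the compounds shown cannot separate these two changes. As far as these compounds go, it also remains open how a phenyl ring with no further group would compare, or one bearing an amine or a carboxylic acid, and whether any such ring would match 4-methoxyphenyl at this position.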